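Chloro for hydrogen on two related cores: working notes

The source may hold more compounds than are shown below. What is called first, only, known or untested is meant among the compounds shown, and "the series" means these compounds.

Measured so far in a functional assay on cells (Cancer cell lines, Homo sapiens) for cytotoxicity, with a stated time of 48 h; on this read-out lower numbers stand for stronger inhibition of growth and higher numbers for weaker inhibition of growth:
compound 1 `COc1c(/C=C2/C(=O)Nc3ccccc32)c2ccccc2n1-c1ccccc1` — 2190 nM
compound 2 `O=C1Nc2ccccc2/C1=C\c1c(Cl)n(CCCc2ccccc2)c2ccccc12` — 16600 nM
compound 3 `COc1c(/C=C2/C(=O)Nc3ccc(Cl)cc32)c2ccccc2n1-c1ccccc1` — 5250 nM

Compound 3 differs from compound 1 by chloro in place of hydrogen on an aromatic carbon; in this assay this change gave a 2.4-fold higher number from compound 1 to compound 3 (0.38 log units; beyond the scatter). Compound 2 stands highest of the three numbers measured; its values against compound 3 and compound 1 both lie beyond the scatter. Compound 2 and compound 1 differ in more than one place, and the difference between the two cores is not broken down here.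

Compound 4 `O=C1Nc2ccc(Cl)cc2/C1=C\c1c(Cl)n(CCCc2ccccc2)c2ccccc12` is not yet measured. It differs from compound 2 by chloro in place of hydrogen on an aromatic carbon, the same change as from compound 1 to compound 3, at a place described in the same words. Going by the values given here, only that one earlier pair shows the change, so the expectation rests on a single step. In this assay the step from compound 2 to compound 4 is expected to be a 2.3-fold higher number from compound 2 to compound 4 (0.36 log units; beyond the scatter), because the matching step was a 2.4-fold higher number from compound 1 to compound 3 (0.38 log units; beyond the scatter). Compound 4 is therefore estimated at 38000 nM, with a range from 15000 nM to 100000 nM.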

Compound 4, concentration for 50% growth inhibition: 2820 nM
Compound 4: middle estimate off by 13-fold (1.13 log units), on the high side, outside the stated range (below it).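

In this assay, chloro in place of hydrogen on an aromatic carbon gives a 5.9-fold lower number from compound 2 to compound 4 (0.77 log units; beyond the scatter), so the change does not keep its direction from one core to the other. Set side by side, the two steps run in opposite directions: the same change on two cores in this assay, a 2.4-fold higher number (0.38 log units; beyond the scatter) from compound 1 to compound 3 and a 5.9-fold lower number (0.77 log units; beyond the scatter) from compound 2 to compound 4, 14-fold (1.15 log units) apart, beyond the scatter of two such steps. The step on one core is therefore a poor guide to the step on the other in this series, but these results do not show which difference between the cores goes with the reversal, and with one pair per core they give no general rule.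

From the compounds shown here alone, compound 1 and compound 2 differ in more than one place, so it remains open whether the reversal follows the methoxy and phenyl groups of compound 1 or the chloro and phenylpropyl groups of compound 2, which a core carrying methoxy with the phenylpropyl chain could help to separate. Also open, going by these compounds, is whether fluoro or bromo in place of the same hydrogen would follow the chloro steps on either core.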